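The compounds below may be only part of what the source reports. "The series", "measured", "known", "first", "only" and "open" are said of these compounds alone.

Working notes on the series. Compound 1 `Oc1ccc(/C=C/C[C@H]2C[C@@H]([C@@H](O)c3ccccc3)CO[C@@H]2c2ccccc2)cc1` gives 14400 nM in a functional assay on HeLa cells (Homo sapiens) for cytotoxicity, read by WST assay, with a stated time of 48 h (a higher number here means a weaker inhibitor, a lower number a stronger inhibitor), the lowest of the three numbers. Compound 2 `COc1cccc([C@H](O)[C@H]2CO[C@@H](c3ccc(OC)c(OC)c3)[C@H](C/C=C/c3ccc(OC)c(OC)c3)C2)c1` gives 18600 nM in this assay, within the scatter of compound 1. Compound 3 `COc1ccc([C@H](O)[C@H]2CO[C@@H](c3ccc(OC)c(OC)c3)[C@H](C/C=C/c3ccc(OC)c(OC)c3)C2)cc1` gives 32200 nM in this assay, beyond the scatter of compound 1. For the measured compounds named here, the only measured step, a 1.7-fold higher number from compound 2 to compound 3 (0.24 log units; within the scatter), concerns the group on the saturated chain carbon and is within the scatter. Compound 4 `O=[N+]([O-])c1ccccc1/C=C/C[C@H]1C[C@@H]([C@@H](O)c2ccccc2)CO[C@@H]1c1ccccc1` differs from compound 1 by 2-nitrophenyl in place of 4-hydroxyphenyl on a double-bonded chain carbon bound to a double-bonded chain carbon. Going by the values given here, no measured step touches this position, so nothing bears directly on it. With only a within-scatter step elsewhere, the step of a 1.1-fold higher number from compound 1 to compound 4 (0.05 log units; within the scatter) is expected to stay within the scatter. Compound 4 is therefore estimated at 16000 nM, between 6000 nM and 45000 nM.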

Compound 4, half-maximal inhibitory concentration: 11800 nM
Beside the measured number, compound 4's estimate is 1.4-fold (0.13 log units) above it; the range from low to high includes it.
By their numbers in this assay, from the lowest: compounds 4, 1, 2 and 3 (each within the scatter of the next, the first and the last beyond it).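

The exchange at this position, with 2-nitrophenyl in place of 4-hydroxyphenyl, gives a 1.2-fold lower number from compound 1 to compound 4 (0.09 log units; within the scatter) in this assay. The entering group has no hydrogen-bond donor, so the hydroxy group of compound 1 is not needed to hold a number in this range, at least for this pair. Nothing at hand explains the result.

The compounds shown do not separate the identity of the group from its place on the ring, which 4-nitrophenyl or 2-hydroxyphenyl would address. As far as these compounds go, whether an amine or a carboxylic acid on this ring would move the number beyond the scatter also remains open.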